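A few compounds are considered here, and "the series" means these few. Any claim that something is new, unique, unknown or untested is made for them only; others in the source may bear on it.

Notes on the series. In an assay on isolated protein for inhibition of Fatty-acid amide hydrolase 1 (Homo sapiens), read by fluorescence, with a stated time of 30 min (a lower number here means a stronger inhibitor, a higher number a weaker inhibitor), compound 1 `CCOC(=O)c1cc(-c2cccc(OC(=O)NC3CCCCC3)c2)n(-c2ccc(C(F)(F)F)cc2)n1` gives 132 nM and compound 2 `CCOC(=O)c1cc(-c2cccc(OC(=O)NC3CCCCC3)c2)n(-c2ccc(Cl)cc2Cl)n1` gives 123 nM; the step of a 1.1-fold lower number from compound 1 to compound 2 (0.03 log units; within the scatter) leaves the two alongside each other, so compound 2 stands with compound 1 inside the scatter. Compound 3 `CCOC(=O)c1cc(-c2cccc(OC(=O)NC3CCCCC3)c2)n(Cc2ccccc2)n1` differs from compound 2 by benzyl in place of 2,4-dichlorophenyl on an aromatic nitrogen. For the measured compounds named here, the only measured step, from compound 1 to compound 2, swapped one aryl for another on the same nitrogen; no step replaces an aryl by a benzyl, so the data give no direction. Compound 3 is therefore expected near compound 2, step a 1.3-fold higher number from compound 2 to compound 3 (0.11 log units; within the scatter), estimate 160 nM within 40 nM to 650 nM.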

Compound 3, half-maximal inhibitory concentration: 70 nM
Compound 3: the middle estimate sits 2.3-fold (0.36 log units) above what was measured, within the range that was stated.
By their numbers in this assay, from the lowest: compounds 3, 2 and 1 (each within the scatter of the next).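

In this assay, the aromatic nitrogen accepts benzyl as well as the two aryl groups: a 1.8-fold lower number from compound 2 to compound 3 (0.24 log units; within the scatter) and a 1.9-fold lower number from compound 1 to compound 3 (0.28 log units; within the scatter). Both steps stay within the scatter, so compounds 1, 2 and 3 cannot be separated, and this position shows no demand for a directly attached aryl ring among these three compounds.

Going by these compounds, it remains open whether a longer alkyl chain on this nitrogen, or a benzyl carrying an amine or a carboxylic acid, would stay alongside them. No available evidence bears on this result.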